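The source may report more compounds than this note shows. Statements on the series, on what has been measured and on what is new or still open speak of the compounds shown alone.

Measured compounds:
- Compound 1, `CCOC(=O)c1cnc(-c2cccs2)nc1NN1C(=O)C=C(C)C1=O`, gives 20 nM in a functional assay on Jurkat cells for inhibition of nuclear factor NF-kappa-B complex (Homo sapiens); on this read-out lower numbers stand for stronger inhibition and higher numbers for weaker inhibition.
- Compound 2, `CCOC(=O)c1cnc(C(=O)c2ccco2)nc1NN1C(=O)C=C(C)C1=O`, gives 700 nM in this assay.
- Compound 3, `CC1=CC(=O)N(Nc2nc(-c3cccs3)ncc2-c2cc(C)no2)C1=O`, gives 300 nM in this assay.

Among these three, compound 3 stands second highest: compound 1 is well below it and compound 2 somewhat above it. The step from compound 1 to compound 3 was a 15-fold higher number from compound 1 to compound 3 (1.18 log units; beyond the scatter), while the unrelated step from compound 1 to compound 2 was a 35-fold higher number from compound 1 to compound 2 (1.54 log units; beyond the scatter).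

Compound 4, `CC1=CC(=O)N(Nc2nc(-c3cccs3)ncc2C#N)C1=O`, is not yet measured. It differs from compound 3 in one place: cyano in place of 3-methyl-1,2-oxazol-5-yl on an aromatic carbon. Going by the values given here, the only measured step that bears on this position is the one from compound 1 to compound 3, where the ethoxycarbonyl of compound 1 gave way to the 3-methyl-1,2-oxazol-5-yl group and the number rose by a 15-fold higher number from compound 1 to compound 3 (1.18 log units; beyond the scatter). That step shows the position is sensitive, and that the weaker number belongs to the group now leaving. Cyano is neither of the two groups already seen there, so the data allow only a partial reading. Compound 4 is therefore expected to move back toward compound 1, with an estimated step of a 4.3-fold lower number from compound 3 to compound 4 (0.63 log units; beyond the scatter) in this assay. The estimate for compound 4 is 70 nM, with a range from 15 nM to 300 nM.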

Compound 4, half-maximal inhibitory concentration: 5000 nM
The estimate for compound 4 lay 71-fold (1.85 log units) below the measured number; measured number outside the range, above it.
By their numbers in this assay, from the lowest: compound 1; then compound 3; then compound 2; then compound 4.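

The result shows that the 3-methyl-1,2-oxazol-5-yl group of compound 3 does not mark the weak end of this position on the six-membered aromatic ring: in this assay, cyano in its place gives a 17-fold higher number from compound 3 to compound 4 (1.22 log units; beyond the scatter) and a clear further loss of inhibition. Set against the ethoxycarbonyl group, the same cyano group gives a 250-fold higher number from compound 1 to compound 4 (2.40 log units; beyond the scatter) in this series, so the three groups seen at this position now span a much wider range than the earlier compounds revealed, with ethoxycarbonyl giving the lowest number, 3-methyl-1,2-oxazol-5-yl the middle one and cyano the highest. The compounds shown carry no measurement that accounts for this order.

The compounds shown leave open whether the low number of compound 1 is particular to the ethyl ester, or would also be seen with a carboxylic acid, a primary amide or a longer ester chain at this position. They also leave open whether the same order of groups would hold with the (furan-2-yl)carbonyl group of compound 2 in place of thiophen-2-yl.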